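Working notes: compounds 1 to 3 in a cell growth assay

This account rests on a few compounds, and the source may have more. Where it says the series, first, only, none or still open, it means among the compounds named here.

Measured so far:
compound 1, `COc1cccc(NC(=O)CSc2nc(Nc3ccccc3)c3ccccc3n2)c1` — 21700 nM
compound 2, `C=CC(=O)Nc1cccc(NC(=O)CSc2nc(Nc3ccccc3Br)c3ccccc3n2)c1` — 15200 nM

Both compounds were run in a functional assay on MDA-MB-231 cells (Homo sapiens) for inhibition, read by MTT assay, with a stated time of 72 h; a lower number here means a stronger inhibitor, a higher number a weaker inhibitor. Compound 1 gives 21700 nM and compound 2 gives 15200 nM. Compound 2 has the lower of the two numbers, but the gap to compound 1 lies within the scatter, so the two cannot be told apart on these readings and neither is called the stronger one.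

Compound 3, `C=CC(=O)Nc1cccc(NC(=O)CSc2nc(Nc3ccc(Cl)c(Cl)c3)c3ccccc3n2)c1`, has not been measured. It differs from compound 2 in one place: 3,4-dichlorophenyl in place of 2-bromophenyl on a nitrogen on an aromatic ring. Going by the values given here, no step between measured compounds of this kind is available, and the two values in hand give no lever for judging a swap of halogenated phenyl groups on this nitrogen.

With nothing to build on beyond the values of compound 1 and compound 2, the step of a 1.3-fold lower number from compound 2 to compound 3 (0.10 log units; within the scatter) is expected to be small, in either direction, and possibly none beyond the scatter. In this assay compound 3 is therefore expected to give 12000 nM, with a range from 4000 nM to 40000 nM.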

Compound 3, half-maximal inhibitory concentration: 17700 nM
Compound 3: the middle estimate sits 1.5-fold (0.17 log units) below what was measured; the measured number falls inside the stated range.
By their numbers in this assay, from the lowest: compounds 2, 3 and 1 (each within the scatter of the next).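

In this assay, going by these compounds alone, the only step at this position reads a 1.2-fold higher number from compound 2 to compound 3 (0.07 log units; within the scatter) and gives the first direct reading of a change on this nitrogen: 3,4-dichlorophenyl in place of 2-bromophenyl does not separate the two compounds. The step exchanges one bromine for two chlorine atoms and also changes the naming positions on the phenyl ring, so it cannot be divided into separate contributions from the kind, number or placement of halogen. No measurement in hand offers an explanation for this reading.

On these data alone, what remains open is how far the result extends beyond these two halogenated phenyl groups, since a single step within the scatter does not show that this position is insensitive to change in general. A phenyl ring carrying an amine or a carboxylic acid, or a longer alkyl chain on this nitrogen in place of the phenyl ring, lies outside the compounds shown, and compound 1 differs from compound 2 and compound 3 in more than one place, so it gives no reading of this position.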